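Compound 4 and the Clearance of Compound 3

A few compounds are considered here, and "the series" means these few. Any claim that something is new, unique, unknown or untested is made for them only; others in the source may bear on it.

Compound 1 (`C[C@@H]1CN(c2sc(C(F)(F)F)nc2-c2nc3ccccc3[nH]2)CCN1C(=O)Cn1cnc2cccnc21`) gives 89 mL.min-1.g-1
Compound 2 (`CCOc1ncc(-c2nc(C(F)(F)F)sc2N2CCN(C(=O)Cn3cnc(C(F)(F)F)n3)[C@H](C)C2)cn1`) gives < 10 mL.min-1.g-1 as a limit of the assay
Compound 3 (`CCc1ncc(-c2nc(C(F)(F)F)sc2N2CCN(C(=O)Cn3nc(C)nc3C)[C@H](C)C2)cn1`) gives 43 mL.min-1.g-1

In a toxicity assay on microsomes from liver (Homo sapiens) for metabolic stability, read by LC-MS, using NADPH, tested at 1 uM (a lower number here means slower removal, a higher number faster removal of the compound), compound 3 gives 43 mL.min-1.g-1 and holds the lower of the two true numbers, while compound 1 gives 89 mL.min-1.g-1 and lies higher, beyond the usual scatter. For compound 2 the result of < 10 mL.min-1.g-1 is a limit and not a number.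

Compound 4 (`Cc1nc(C)n(CC(=O)N2CCN(c3sc(C(F)(F)F)nc3-c3ccc(C(F)(F)F)nc3)C[C@H]2C)n1`) has not yet been measured. It carries 6-(trifluoromethyl)pyridin-3-yl in place of 2-ethylpyrimidin-5-yl on an aromatic carbon. For the measured compounds named here, no measured pair of compounds differs in this one place, so the expectation is a loose one. A small step toward slower removal is expected, not clearly beyond the usual scatter, and the estimated step is a 1.6-fold lower number from compound 3 to compound 4 (0.20 log units; within the scatter) in this assay as a working figure. The estimate for compound 4 is 27 mL.min-1.g-1 with 11 mL.min-1.g-1 and 60 mL.min-1.g-1 as the expected ends of its range.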

Compound 4, intrinsic clearance in microsomes: < 10 mL.min-1.g-1
Compound 4: a limit, no number (the forecaster's own chance of this, stated with the estimate: 15%); middle value at least 2.7-fold (0.43 log units) away from the limit.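

In this assay, 6-(trifluoromethyl)pyridin-3-yl in place of 2-ethylpyrimidin-5-yl on an aromatic carbon of the five-membered ring gives an at least 4.3-fold lower number from compound 3 to compound 4 (0.63 log units; beyond the scatter). For the compounds shown here, the earlier compounds differ from one another in more than one place, and this pair is the first to isolate this position, showing that the group there can alone shift the clearance beyond the usual scatter. The result for compound 4 is a limit and not a number, and the step can be read only as a minimum: the limit of < 10 mL.min-1.g-1 in this assay, at which 2 of the 4 values shown sit.

The trifluoromethyl group and the ring with one hetero atom enter together, leaving open which of them goes with the step. Also open, as far as these compounds go, is whether a nitrile or a primary amine in place of that trifluoromethyl group would give a similar result.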